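Swapping a methoxyphenyl for a methylfuranyl on the shared core

The compounds below may be only part of what the source reports. "The series", "measured", "known", "first", "only" and "open" are said of these compounds alone.

Measured compounds:
- compound 1, `N#CC1=C(N)N(c2ccc(S(N)(=O)=O)cc2)C2=C(CCCC2)C1c1ccc(O)cc1`: 42%
- compound 2, `COc1ccc(C2C(C#N)=C(N)N(c3ccc(S(N)(=O)=O)cc3)C3=C2CCCC3)cc1`: 90%
- compound 3, `COc1ccc(C2C(C#N)=C(N)N(c3ccc(S(N)(=O)=O)cc3)C3=C2CCCC3)c2ccccc12`: 5%

In a functional assay on Ehrlich cells (Mus musculus) for cytotoxicity, read by trypan blue exclusion, with a stated time of 2 h, tested at 25 ug/mL (on this read-out lower numbers stand for a weaker effect and higher numbers for a stronger effect at the one concentration tested), compound 2 gives the highest of the three numbers. Its nearest neighbour is compound 1, whose value is 42%, and the furthest is compound 3, whose value is 5%; both gaps are beyond the scatter.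

Compound 4, `Cc1ccc(C2C(C#N)=C(N)N(c3ccc(S(N)(=O)=O)cc3)C3=C2CCCC3)o1`, is not yet measured. It differs from compound 2 in one place: 5-methylfuran-2-yl in place of 4-methoxyphenyl on a saturated ring carbon.

For the measured compounds named here, only one step is known within this set, a number 48 percentage points higher from compound 1 to compound 2 (beyond the scatter), and it concerns a methyl in place of hydrogen on an oxygen, not the exchange of the whole ring that carries it. Going by the values given here, compound 3 shows that adding a fused ring on that part of the molecule goes with a much lower value than compound 2, but no step is given for that pair. Among the compounds with values here, no measured step bears directly on 5-methylfuran-2-yl in place of 4-methoxyphenyl, so the size and direction of the change remain open.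

Compound 4 is therefore estimated at 50%, with a wide range from 15% to 88%. This estimate means an expected step of a number 40 percentage points lower from compound 2 to compound 4 (beyond the scatter).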

Compound 4, a percentage reported as activity, at one concentration (the size of the read-out at that concentration, not a potency): 10%
For compound 4 the middle estimate is 40 percentage points above the measured one; measured number below the stated range.
By their numbers in this assay, from the lowest: compounds 3 and 4 (each within the scatter of the next); then compound 1; then compound 2.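

In this assay, the group on this saturated ring carbon matters as a whole ring, and not only through the small change on its oxygen seen earlier: 5-methylfuran-2-yl in place of 4-methoxyphenyl gives a number 80 percentage points lower from compound 2 to compound 4 (beyond the scatter), a large step. The same furan group also falls short of the 4-hydroxyphenyl group, with a number 32 percentage points lower from compound 1 to compound 4 (beyond the scatter), so among these three compounds, which differ only at this carbon, compound 4 gives the lowest number and a phenyl ring bearing either oxygen group gives a higher one. Nothing available explains why the exchange goes with such a drop.

The compounds shown cannot separate the effect of the five-membered ring from that of its ring oxygen or its methyl group, and a plain furan-2-yl, a 5-methylthiophen-2-yl or an unsubstituted phenyl on this carbon would be needed to pull these apart. As far as these compounds go, it also stays open whether a six-membered aromatic ring carrying an amine or a carboxylic acid in place of the methoxy group would keep the high number of compound 2.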